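A few compounds are considered here, and "the series" means these few. Any claim that something is new, unique, unknown or untested is made for them only; others in the source may bear on it.

Measured so far in an ADME assay on microsomes from liver (Homo sapiens) for metabolic stability; a lower number here means slower removal, a higher number faster removal of the compound:
Compound 1 `CC(=O)N[C@@H]1CCC[C@H](C(=O)Nc2cc(-c3cnc(C)n3C(C)C)ccn2)C1`: 3.6 mL.min-1.g-1
Compound 2 `CC(=O)N[C@@H]1CCC[C@H](C(=O)Nc2cc(-c3cnc4n3CCC4)c(Cl)cn2)C1`: 9.7 mL.min-1.g-1

Of these two compounds, compound 2 stands highest at 9.7 mL.min-1.g-1, while compound 1 gives the lower number at 3.6 mL.min-1.g-1, a gap beyond the usual scatter. Compound 3 `CC(=O)N[C@@H]1CCC[C@H](C(=O)Nc2cc(-c3cnn4c3NCCC4)c(Cl)cn2)C1` has not yet been measured. It keeps the rest of compound 2, including the chloro group, and differs in one group on an aromatic carbon, opposite the ring nitrogen: a group of 9 heavy atoms (6 carbon, 3 nitrogen; one five-membered aromatic ring with 2 hetero atoms, one six-membered non-aromatic ring with 2 hetero atoms) in place of a group of 8 heavy atoms (6 carbon, 2 nitrogen; one five-membered non-aromatic ring with 1 hetero atom, one five-membered aromatic ring with 2 hetero atoms), on an aromatic carbon. A five-membered non-aromatic ring with 1 hetero atom gives way to a six-membered non-aromatic ring with 2 hetero atoms. Within the data shown here, no pair of measured compounds differs in one place only, so the data give no direct guide to this change. With no direction established, no step beyond the scatter is expected in this assay, and the expectation stays close to compound 2 at 9.7 mL.min-1.g-1. The estimate means a 1.2-fold lower number from compound 2 to compound 3 (0.08 log units; within the scatter), an expected step within the scatter. For compound 3 the estimated clearance is 8 mL.min-1.g-1, with an expected range from 3.5 mL.min-1.g-1 to 18 mL.min-1.g-1.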

Compound 3, intrinsic clearance in microsomes: 6.2 mL.min-1.g-1
Compound 3: middle estimate off by 1.3-fold (0.11 log units), on the high side, within the range that was stated.
By their numbers in this assay, from the lowest: compounds 1, 3 and 2 (each within the scatter of the next, the first and the last beyond it).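

Measured in this assay, the exchange of the two fused ring groups gives a 1.6-fold lower number from compound 2 to compound 3 (0.19 log units; within the scatter) on the aromatic carbon opposite the ring nitrogen, ortho to a chloro group. Among these compounds, this is the first step in which only one place differs, and it shows that, with the chloro group kept, a six-membered non-aromatic ring with 2 hetero atoms can take the place of a five-membered non-aromatic ring with 1 hetero atom without a step beyond the scatter, even as 1 hydrogen-bond donor enters where the leaving group had none. No measurement at hand bears on why the step is this size.

From the compounds shown here alone, compound 1 differs from compound 2 and compound 3 in more than one place, so what the chloro group itself contributes to the read-out remains open. Also open, going by these compounds, is how this position would respond to a group of a different kind, such as a phenyl ring or a morpholine, and whether a fluoro group in place of the chloro group would leave the number within the scatter.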